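Methoxy in Place of Fluoro on Compound 2

The compounds below may be only part of what the source reports. "The series", "measured", "known", "first", "only" and "open" are said of these compounds alone.

In a functional assay on PC-3 cells (Homo sapiens) for cytotoxicity, read by MTT assay, with a stated time of 48 h (on this read-out lower numbers stand for stronger inhibition and higher numbers for weaker inhibition), compound 1 `COc1ccc2c(c1)nc(/C=C1\SC(=S)N(CC(=O)O)C1=O)n2Cc1ccc(C)cc1` gives 3640 nM. Compound 2 `O=C(O)CN1C(=O)/C(=C/c2nc3cc(F)ccc3n2Cc2ccccc2F)SC1=S` gives > 50000 nM, which is a limit of the assay and not a number. Its true value is therefore unknown, and any comparison with it can only be rough.

Compound 3 `COc1ccc2c(c1)nc(/C=C1\SC(=S)N(CC(=O)O)C1=O)n2Cc1ccccc1F` is compound 2 with one change, methoxy in place of fluoro on an aromatic carbon. Going by the values given here, no measured pair of compounds shows this change alone, so the evidence is thin. Among the compounds with values here, compound 1 carries the same methoxy and gives 3640 nM, which is the only guide, and it suggests that compound 3 may give a real number. In this assay, the expected move is toward stronger inhibition, an estimated at least 5.5-fold lower number from compound 2 to compound 3 (0.74 log units; beyond the scatter). Compound 3 is expected at about 9000 nM, with an estimated range of 2500 nM to 50000 nM.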

Compound 3, half-maximal inhibitory concentration: 24700 nM
Compound 3: the middle estimate sits 2.7-fold (0.44 log units) below what was measured; the range from low to high includes it.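

Methoxy in place of fluoro on this aromatic carbon brings a real number in this assay, and the step is an at least 2.0-fold lower number from compound 2 to compound 3 (0.30 log units; that floor lies within the scatter). Compound 2 has only a limit of the assay, so this step is a floor and its true size is unknown: the limit of > 50000 nM in this assay, at which 1 of the 3 values shown sits.

The methoxy alone does not set the level of compound 1, since with the same methoxy, 2-fluorophenyl in place of 4-methylphenyl gives a 6.8-fold higher number from compound 1 to compound 3 (0.83 log units; beyond the scatter), so the group on the saturated chain carbon also moves the number.

Going by these compounds, how other groups at this aromatic carbon, such as a chlorine or an amine, would read stays open. Also open, on these data alone, is how fluoro at this carbon would read alongside 4-methylphenyl, which would show whether the two changes act independently.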